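This account rests on a few compounds, and the source may have more. Where it says the series, first, only, none or still open, it means among the compounds named here.

Three compounds share one core and differ only in the group on the aniline ring. Compound 1 `CC1(C)C[C@H](O)C[C@](C)(CNc2cc(F)cc(Cl)c2)C1` carries fluoro and chloro, compound 2 `CC1(C)C[C@H](O)C[C@](C)(CNc2cccc(C(N)=O)c2)C1` a carbamoyl group, and compound 3 `CC1(C)C[C@H](O)C[C@](C)(CNc2cccc(S(N)(=O)=O)c2)C1` a sulfamoyl group. In an ADME assay on MDCK cells (Canis lupus familiaris) for cytotoxicity, read by MTT assay, with a stated time of 3 days (on this read-out lower numbers stand for higher toxicity in this test and higher numbers for lower toxicity in this test), compound 1 gives 4400 nM. Compound 2 gives > 100000 nM in this assay, which is a limit of the assay and not a number. Compound 3 gives > 100000 nM in this assay, again a limit. The step that the two limits leave unreadable from compound 2 to compound 3 is therefore unreadable. Compound 3 thus stands at the limit of > 100000 nM in this assay, at which 2 of the 3 values shown sit, with no number of its own.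

The next compound, compound 4 `CC1(C)C[C@H](O)C[C@](C)(CNc2cc(F)cc(S(N)(=O)=O)c2)C1`, differs from compound 3 by fluoro in place of hydrogen on an aromatic carbon. No measured step among these compounds bears directly on adding a fluoro to a ring that already carries a sulfamoyl group; the only ring with halogens is that of compound 1, which gives 4400 nM in this assay but carries chloro as well and no sulfamoyl. Compound 4 is therefore expected to stay near the limit, with an estimated 80000 nM in this assay, a range of 20000 nM to 200000 nM, and an expected step of an at least 1.2-fold lower number from compound 3 to compound 4 (0.09 log units; that floor lies within the scatter) that is likely small.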

Compound 4, half-maximal cytotoxic concentration: 55000 nM
Compound 4: the middle estimate sits 1.5-fold (0.16 log units) above what was measured; measured number inside the range.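

Among these compounds, compound 4 is the first compound with a sulfamoyl group to give a number rather than a limit in this assay, so this position, meta to a sulfamoyl group, is one where fluoro in place of hydrogen leaves a readable value. The step is an at least 1.8-fold lower number from compound 3 to compound 4 (0.25 log units; that floor lies within the scatter), which does not establish a change beyond the scatter, and its true size stays unknown because compound 3 has no number of its own: the limit of > 100000 nM in this assay, at which 2 of the 4 values shown sit.

Compound 1 and compound 4 share the fluoro and differ in one place, and that change gives a 13-fold higher number from compound 1 to compound 4 (1.10 log units; beyond the scatter), so the fluoro on the ring does not by itself bring compound 4 down to the number of compound 1.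

The compounds shown leave open whether a fluoro at the same place would give a readable number on the ring of compound 2, which carries a carbamoyl group. They also leave open how a methyl group, a nitrile or a second chloro in place of this fluoro would read beside the sulfamoyl group.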